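This account rests on a few compounds, and the source may have more. Where it says the series, first, only, none or still open, it means among the compounds named here.

Measured compounds in this series:
Compound 1 `Cc1ccc2c(NCc3ccc(NC(=O)C4CCN(Cc5ccccc5)CC4)cc3)nc(N3CCC(N4CCCC4)CC3)nc2c1` gives in a functional assay on SV5A8 cells (Homo sapiens) for cytotoxicity (on this read-out higher numbers stand for weaker inhibition and lower numbers for stronger inhibition), a limit of the assay, > 8090 nM.
Compound 2 `CCN1CCN(c2nc(NCc3ccc(NC(=O)C4CCN(Cc5ccccc5)CC4)cc3)c3ccc(C)cc3n2)CC1` gives in this assay a limit of the assay, > 13000 nM.
Compound 3 `Cc1ccc2c(NCc3ccc(NC(=O)C4CCN(Cc5ccccc5)CC4)cc3)nc(N(C)CCCN(C)C)nc2c1` gives in this assay a limit of the assay, > 8620 nM.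

Compound 3 therefore stands only at a limit, and the two further values shown are limits as well. The three steps among the measured compounds, a step that the two limits leave unreadable from compound 1 to compound 2, a step that the two limits leave unreadable from compound 1 to compound 3 and a step that the two limits leave unreadable from compound 2 to compound 3, are each left unreadable by the limits on both sides, so none of them has a readable size. Going by the values given here, the lines (the limit of > 13000 nM in this assay, at which 1 of the 3 values shown sits), the limit of > 8090 nM in this assay, at which 1 of the 3 values shown sits, and the limit of > 8620 nM in this assay, at which 1 of the 3 values shown sits, show only that each value rests at its own limit.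

Compound 4 `Cc1ccc2c(NCc3ccc(NC(=O)C4CCN(Cc5ccccc5)CC4)cc3)nc(N3CCCCCC3)nc2c1` differs from compound 3 by azepan-1-yl in place of (3-(dimethylamino)propyl)(methyl)amino on an aromatic carbon. Among the compounds with values here, no measured step bears on this exchange with a readable size; what the three measured compounds show is that three different substituents on this aromatic carbon all left the value at a limit in this assay. Compound 4 is therefore expected to sit at a limit as well, with no step beyond the scatter expected, a step that the limit leaves unreadable from compound 3 to compound 4. The estimate for compound 4 in this assay is 15000 nM, with a range from 5000 nM to 50000 nM.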

Compound 4, half-maximal inhibitory concentration: > 6880 nM
Compound 4 ended at the assay's limit; the forecaster's own chance of this, stated with the estimate: 85%; the middle value lies beyond the limit too.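

In this assay compound 4 gives > 6880 nM, a limit of the assay. The steps from compound 1, compound 2 and compound 3 to compound 4 cannot be read, with limits on both sides of each. The compounds shown leave open where each true value lies and whether the four substituents on this aromatic carbon differ at all in this assay.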